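Amide substituent changes in a dihydroxyheptanoic acid series

The source may report more compounds than this note shows. Statements on the series, on what has been measured and on what is new or still open speak of the compounds shown alone.

Measured compounds:
compound 1 `CC(C)c1c(C(=O)NCc2cccc(F)c2F)nn(-c2ccc(F)cc2)c1OC[C@@H](O)C[C@@H](O)CC(=O)O`, 2 nM in an assay on microsomes from liver for inhibition of 3-hydroxy-3-methylglutaryl-coenzyme A reductase (Rattus norvegicus); on this read-out lower numbers stand for stronger inhibition and higher numbers for weaker inhibition
compound 2 `COc1cccc(CNC(=O)c2nn(-c3ccc(F)cc3)c(OC[C@@H](O)C[C@@H](O)CC(=O)O)c2C(C)C)c1`, 16 nM in this assay

Compound 2 stands highest of the two numbers, its nearest neighbour being compound 1, which gives 2 nM. The step of an 8.0-fold higher number from compound 1 to compound 2 (0.90 log units; beyond the scatter) is the only measured one that bears on the next change. Among the compounds with values here, compound 3 `CC(C)c1c(C(=O)N(C)Cc2cccc(F)c2)nn(-c2ccc(F)cc2)c1OC[C@@H](O)C[C@@H](O)CC(=O)O` differs from compound 2 by (3-fluorobenzyl)(methyl)amino in place of (3-methoxybenzyl)amino on a carbonyl carbon; the loss of the amide hydrogen has no measured precedent here. A small return toward the number of compound 1 is expected, so the step of a 1.3-fold lower number from compound 2 to compound 3 (0.12 log units; within the scatter) is estimated as modest, with wide uncertainty. For compound 3 the expected value is 12 nM, in the range 2 nM to 80 nM.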

Compound 3, half-maximal inhibitory concentration: 14 nM
For compound 3 the middle estimate is 1.2-fold (0.07 log units) below the measured one; measured number inside the range.
By their numbers in this assay, from the lowest: compound 1; then compounds 3 and 2 (each within the scatter of the next).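

In this assay, within the data shown here, the step of a 1.1-fold lower number from compound 2 to compound 3 (0.06 log units; within the scatter) puts the first compound without the amide hydrogen level with its secondary amide partner. The step of a 7.0-fold higher number from compound 1 to compound 3 (0.85 log units; beyond the scatter) leaves compound 3 clearly apart from compound 1, so (3-fluorobenzyl)(methyl)amino does not recover the number of (2,3-difluorobenzyl)amino. No measurement here accounts for either step.

As far as these compounds go, this change swaps the ring substituent and adds the methyl on nitrogen together, so their separate contributions remain open. A (3-fluorobenzyl)amino group on the same carbonyl carbon would separate them.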